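The compounds below may be only part of what the source reports. "The series", "measured", "known", "first", "only" and "open" are said of these compounds alone.

Compound 2 `CC(C)n1c(/C=C2/C(=O)Nc3ccc(F)cc32)nc2ccccc21` gives 20800 nM in a functional assay on PC-3 cells (Homo sapiens) for cytotoxicity, read by MTT assay, with a stated time of 48 h; a lower number here means a stronger inhibitor, a higher number a weaker inhibitor. Compound 1 `CCn1c(/C=C2/C(=O)Nc3ccc(F)cc32)nc2ccccc21` returns only a limit in this assay, > 50000 nM, which is the ceiling of the measurement. The change from compound 2 to compound 1 is hydrogen in place of methyl on a saturated chain carbon bound to an aromatic nitrogen and a saturated chain carbon, and it produced an at least 2.4-fold higher number from compound 2 to compound 1 (0.38 log units; beyond the scatter), the reading of compound 1 sitting at the limit of > 50000 nM in this assay, at which 1 of the 3 values shown sits. Compound 3 `CCn1c(/C=C2/C(=O)Nc3ccc(Br)cc32)nc2ccccc21` gives 42700 nM in this assay. From compound 1 to compound 3 the change is bromo in place of fluoro on an aromatic carbon, which gave an at least 1.1-fold lower number from compound 1 to compound 3 (0.06 log units; that floor lies within the scatter); the difference between the cores of compound 2 and compound 3 is not broken down here.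

Compound 4 `Cn1c(/C=C2/C(=O)Nc3ccc(Br)cc32)nc2ccccc21` has not yet been measured in this assay. It differs from compound 3 by hydrogen in place of methyl on a saturated chain carbon bound to an aromatic nitrogen. This is the same kind of change as that from compound 2 to compound 1, though there the place was also bound to a saturated chain carbon. Since that earlier step weakened the inhibitor, compound 4 is expected to sit weaker than compound 3 by a 1.9-fold higher number from compound 3 to compound 4 (0.27 log units; within the scatter), resting on the step of an at least 2.4-fold higher number from compound 2 to compound 1 (0.38 log units; beyond the scatter). The estimate for compound 4 in this assay is 80000 nM, between 30000 nM and 200000 nM.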

Compound 4, half-maximal inhibitory concentration: > 50000 nM
Compound 4 was reported as a limit; the forecaster's own chance of this, stated with the estimate: 65%; the middle value lies beyond the limit too.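

In this assay compound 4 gives > 50000 nM, which is a limit of the assay and not a number. Carried to the bromo-bearing core, the change gave an at least 1.1-fold higher number from compound 3 to compound 4 (0.06 log units; that floor lies within the scatter), so the number moved the same way on both cores, but on this core only a floor is known, and that floor lies within the scatter. The result therefore does not show that the change carries over with the same size, nor that its size differs from one core to the other, and the two steps compare as follows: the same change on two cores in this assay, an at least 2.4-fold higher number (0.38 log units; beyond the scatter) from compound 2 to compound 1 and an at least 1.1-fold higher number (0.06 log units; that floor lies within the scatter) from compound 3 to compound 4; the limit leaves it open whether they differ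

The compounds shown leave open how this change would read on a core where both partners stand clear of the ceiling, which part of the series has reached: the limit of > 50000 nM in this assay, at which 2 of the 4 values shown sit. What a longer chain such as butyl would do in this place, or an amine in place of the bromo or fluoro group, also stays open.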